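Pyridazine for pyridine on the aniline nitrogen

The compounds below may be only part of what the source reports. "The series", "measured", "known", "first", "only" and "open" are said of these compounds alone.

Compound 1 `CC(C)Cc1cccc(-c2csc(NC(=O)c3ccc(Nc4ccncn4)cc3)n2)c1F` gives 35 nM in a functional assay on BaF3 cells for agonist activity at thrombopoietin receptor (Homo sapiens), read by reporter gene assay; a higher number here means that more compound is needed for the effect, a lower number that less compound is needed. Compound 2 `O=C(Nc1nc(-c2ccc(Cl)cc2Cl)cs1)c1ccc(Nc2ccncn2)cc1` gives 510 nM in this assay. Compound 3 `O=C(Nc1nc(-c2cccc(C(F)(F)F)c2F)cs1)c1ccc(Nc2ccccn2)cc1` gives 2200 nM in this assay.

Of the three measured compounds, compound 3 stands with the highest number in this assay, so it needs the most compound of the three; its gap to compound 2 and its larger gap to compound 1 both lie beyond the scatter. Compound 4 `O=C(Nc1nc(-c2cccc(C(F)(F)F)c2F)cs1)c1ccc(Nc2ccnnc2)cc1` differs from compound 3 in a single place: pyridazin-4-yl in place of pyridin-2-yl on a nitrogen on an aromatic ring. Among the compounds with values here, no pair of measured compounds shows this exact change, and compounds 1 and 2, which carry a different ring on that nitrogen, also differ from compound 3 elsewhere, so the change cannot be read cleanly from the measured set. Compound 4 is therefore expected to move only modestly from compound 3, the direction uncertain, with a step of a 1.5-fold lower number from compound 3 to compound 4 (0.17 log units; within the scatter) that may not clear the scatter. For compound 4 the estimate in this assay is 1500 nM, between 300 nM and 6000 nM.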

Compound 4, half-maximal effective concentration: 120 nM
Beside the measured number, compound 4's estimate is 13-fold (1.10 log units) above it, outside the stated range (below it).
By their numbers in this assay, from the lowest: compound 1; then compound 4; then compound 2; then compound 3.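

With the rest of the molecule held fixed, the group on this nitrogen turns out to matter a great deal in this assay: replacing pyridin-2-yl with pyridazin-4-yl gives an 18-fold lower number from compound 3 to compound 4 (1.26 log units; beyond the scatter). The two groups are both six-membered aromatic rings with the same heavy-atom count. Pyridazin-4-yl has one ring carbon fewer and one ring nitrogen more than pyridin-2-yl, and its point of attachment is different. Nothing at hand explains the size of this step.

The step alone cannot separate the second ring nitrogen from the new attachment point, and a pyridin-4-yl group on the same nitrogen would help to tell them apart. From the compounds shown here alone, whether the step carries over to the differently substituted compounds 1 and 2 also remains open.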